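The compounds below may be only part of what the source reports. "The series", "measured", "known", "first", "only" and "open" are said of these compounds alone.

Measured compounds:
compound 1 `O=C(CCCCCCNC(=O)C(O)(O)C(F)(F)F)Nc1nc2ccccc2s1` — 82000 nM
compound 2 `O=C(CCCCCCNC(=O)C(O)(O)C(F)(F)F)Nc1ncc(-c2ccccc2)s1` — 350000 nM

Both were run in an assay on isolated protein for inhibition of protein deacetylase HDAC6 (Homo sapiens), read by chemiluminescence, with a stated time of 3 h; on this read-out higher numbers stand for weaker inhibition and lower numbers for stronger inhibition. Compound 1 gives the lower of the two numbers, and compound 2 stands well away from it, beyond the scatter. Compound 3 `O=C(CCCCCCNC(=O)C(O)(O)C(F)(F)F)Nc1ccc(Br)cc1` has not been measured. It differs from compound 1 in one place: 4-bromophenyl in place of 1,3-benzothiazol-2-yl on an amide-type nitrogen. Among the measured compounds shown here, no change of this kind has been measured, so no measured step supports a direction. Given that the only cap change seen, compound 1 to compound 2, weakened inhibition, a modest step upward in this assay is expected, a 1.8-fold higher number from compound 1 to compound 3 (0.26 log units; within the scatter), with a real chance of none beyond the scatter. For compound 3 the estimate is 150000 nM, within 40000 nM to 600000 nM.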

Compound 3, half-maximal inhibitory concentration: 100000 nM
Estimate against measurement, compound 3: 1.5-fold (0.18 log units) above; the range from low to high includes it.
By their numbers in this assay, from the lowest: compounds 1 and 3 (each within the scatter of the next); then compound 2.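

In this assay the change of cap on the amide-type nitrogen, 4-bromophenyl in place of 1,3-benzothiazol-2-yl, gives a 1.2-fold higher number from compound 1 to compound 3 (0.09 log units; within the scatter). At this position, the five-membered aromatic ring with its hetero atoms is therefore not needed to stay within the scatter of compound 1, and a single six-membered aromatic ring of carbon only, carrying bromine, suffices. Nothing available bears on why these two groups read alike.

On these data alone, whether an amine or a carboxylic acid in place of the bromine would separate from compound 1 remains open. As far as these compounds go, the effect of a longer chain in the shared core also remains open.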